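Methyl on a Fused Ring: Two Cores, One Change

The compounds below may be only part of what the source reports. "The series", "measured", "known", "first", "only" and "open" are said of these compounds alone.

Three compounds have so far been measured in an assay on cells for inhibition of matrix metalloproteinase-9 (Homo sapiens), read by fluorescence, with stated times of 15 min and 4 h; a lower number here means a stronger inhibitor, a higher number a weaker inhibitor:
compound 1, `O=C(CCc1ccccc1)Nc1cccc(-c2nc3ccccc3[nH]2)c1`, gives 68000 nM
compound 2, `Cc1cccc2nc(-c3cccc(NC(=O)CCc4ccccc4)c3)[nH]c12`, gives 60000 nM
compound 3, `O=[N+]([O-])c1ccc(-c2nc3ccccc3o2)cc1`, gives 36000 nM

Compound 1 and compound 2 share a core and differ by methyl in place of hydrogen on an aromatic carbon; in this assay this made a 1.1-fold lower number from compound 1 to compound 2 (0.05 log units; within the scatter). Compound 3 rests on another core, and the difference between the two cores is not broken down here. Its number is the lowest of the three, yet its distances to compound 2 and to compound 1 both lie within the scatter, so no order among them is claimed.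

Compound 4, `Cc1ccc2nc(-c3ccc([N+](=O)[O-])cc3)oc2c1`, is not yet measured. It differs from compound 3 by methyl in place of hydrogen on an aromatic carbon. This is the same kind of change as that between compound 1 and compound 2, though not the same: in compound 2 the methyl sits ortho to a fused ring and meta to a fused ring, whereas in compound 4 it sits meta to a fused ring and para to a fused ring. The earlier methyl made only a 1.1-fold lower number from compound 1 to compound 2 (0.05 log units; within the scatter). On that basis a step of similar size is expected in this assay, a 1.1-fold lower number from compound 3 to compound 4 (0.05 log units; within the scatter). For compound 4 the estimate is 32000 nM, with a likely range from 12000 nM to 85000 nM.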

Compound 4, half-maximal inhibitory concentration: 18000 nM
The estimate for compound 4 lay 1.8-fold (0.25 log units) above the measured number; measured number inside the range.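

In this assay, methyl in place of hydrogen on an aromatic carbon of the core of compound 3 gave a 2.0-fold lower number from compound 3 to compound 4 (0.30 log units; within the scatter). Set beside the same change on the other core, the two steps cannot be told apart: the same change on two cores in this assay, a 1.1-fold lower number (0.05 log units; within the scatter) from compound 1 to compound 2 and a 2.0-fold lower number (0.30 log units; within the scatter) from compound 3 to compound 4, 1.8-fold (0.25 log units) apart, within the scatter of two such steps. Within the data shown here, this gives no sign that the change behaves differently on the two cores, but it does not show that the change carries over as a rule: each step lies within the scatter, so neither can be told from no effect, there are only two pairs, and the methyl does not sit at the same place on both cores.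

The compounds shown leave open whether any other group on these aromatic carbons, such as a methoxy group, a chlorine or an amine, would give a step beyond the scatter. They also leave open whether a step of that kind, once found on one core, would be repeated on the other.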